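A few compounds are considered here, and "the series" means these few. Any claim that something is new, unique, unknown or untested is made for them only; others in the source may bear on it.

Compound 1 `Cc1cc(C)cc(Cc2ccc3c(NCCCNCc4ccco4)ccnc3c2)c1` is the reference point of this set. In a physicochemical assay for solubility, with a stated time of 18 h, at pH 7.4 (on this read-out higher numbers stand for higher solubility and lower numbers for lower solubility), compound 1 gives 4200 nM. Compound 2 `COc1ccc(Oc2ccc3c(NCCCNCc4cc(F)ccc4OC)ccnc3c2)cc1` gives 14500 nM in this assay, and compound 3 `COc1ccc(F)cc1CNCCCNc1ccnc2cc(Oc3ccc(F)cc3)ccc12` gives 14500 nM in this assay. Compound 1 therefore stands lowest of the three numbers, with compound 2 and compound 3 both beyond the scatter above it. Within the data shown here, the one step between measured compounds, no change at the digits printed from compound 2 to compound 3 (within the scatter), concerns fluoro in place of methoxy on an aromatic carbon and leaves the read-out where it was.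

Compound 4 `c1ccc(Cc2ccc3c(NCCCNCc4ccco4)ccnc3c2)cc1` has not yet been measured. It differs from compound 1 by phenyl in place of 3,5-dimethylphenyl on a saturated chain carbon bound to an aromatic carbon. Among the measured compounds shown here, no measured step touches this part of the series, and the change at a benzyl position has no counterpart among compounds 2 and 3, so the expectation rests on compound 1 alone, whose value 4200 nM anchors it. The step of a 1.4-fold higher number from compound 1 to compound 4 (0.15 log units; within the scatter) is expected to be small and upward if anything, likely within the scatter. Compound 4 is expected to give 6000 nM in this assay, within a range from 2500 nM to 15000 nM.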

Compound 4, solubility: 4200 nM
The estimate for compound 4 lay 1.4-fold (0.15 log units) above the measured number; the range from low to high includes it.
By their numbers in this assay, from the lowest: compounds 1 and 4 (each within the scatter of the next); then compounds 2 and 3 (each within the scatter of the next).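

In this assay, among these compounds, the change from 3,5-dimethylphenyl to phenyl on a saturated chain carbon bound to an aromatic carbon gives no change at the digits printed from compound 1 to compound 4 (within the scatter) and is the first measured step at this position. Going from the 8 heavy atoms of 3,5-dimethylphenyl to the 6 of phenyl therefore does not separate the two compounds on this read-out, with the rest of compound 1 held fixed. No supporting measurement bears on why the read-out holds here.

This single pair leaves open whether the same step would hold with the other parts of the series changed. It also leaves open how the read-out responds when this position carries a group other than these two carbon-only rings, such as a benzyl bearing an amine or a carboxylic acid.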